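Trimming a Benzylic Amino Acid Arm to a Hydroxymethyl

The compounds below may be only part of what the source reports. "The series", "measured", "known", "first", "only" and "open" are said of these compounds alone.

Of the compounds shown here, three built on one shared core have been tested in an ADME assay on NCM460 cells (Homo sapiens) for cytotoxicity, read by CCK-8 assay, with a stated time of 48 h; on this read-out higher numbers stand for weaker inhibition and lower numbers for stronger inhibition. Compound 1 `COc1ccc(/C=C\c2cc(OC)c(OC)c(OC)c2)cc1OCc1ccc(CN2C[C@H](O)C[C@@H]2C(=O)O)cc1` stops at the limit > 50000 nM in this assay, a ceiling of the measurement rather than a number. Compound 2 `COc1ccc(/C=C\c2cc(OC)c(OC)c(OC)c2)cc1OCc1ccc(CN2CC[C@@H](O)C2)cc1` gives 53000 nM in this assay. Compound 3 `COc1ccc(/C=C\c2cc(OC)c(OC)c(OC)c2)cc1OCc1ccc(CN[C@H](C(=O)O)[C@@H](C)O)cc1` likewise reaches only the limit > 50000 nM in this assay. Because two of the three values sit at the limit of > 50000 nM in this assay, at which 2 of the 3 values shown sit, none of the steps between these compounds has a readable size: the step that the limit leaves unreadable from compound 1 to compound 2 is unreadable, as are the steps a step that the two limits leave unreadable from compound 1 to compound 3 and a step that the limit leaves unreadable from compound 2 to compound 3. Going by the values given here, all that can be said is that every value so far lies at or close to the ceiling of this assay.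

Compound 4 `COc1ccc(/C=C\c2cc(OC)c(OC)c(OC)c2)cc1OCc1ccc(CO)cc1` differs from compound 3 by hydroxy in place of (1-carboxy-2-hydroxypropyl)amino on a saturated chain carbon bound to an aromatic carbon. The two measured steps that alter the same position, from compound 1 and from compound 2 to compound 3, bear on this change but offer no size. With nothing readable to build on, the step of a number no higher from compound 3 to compound 4 (the limit leaves the size open) is expected to be none beyond the scatter, leaving compound 4 near the ceiling as well. Compound 4 is therefore estimated at 50000 nM in this assay, within a range from 20000 nM to 120000 nM, with a good chance that only a limit is reported.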

Compound 4, half-maximal inhibitory concentration: > 50000 nM
Compound 4: only a limit was reported (the forecaster's own chance of this, stated with the estimate: 65%); the middle value lies on the limit itself.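

Compound 4 gives > 50000 nM, which is a limit and not a number. The steps joining compound 4 to compound 1, compound 2 and compound 3 cannot be read, because the values stop at the same ceiling: the limit of > 50000 nM in this assay, at which 3 of the 4 values shown sit.

The compounds shown leave open whether any change on this saturated chain carbon shifts the value at all.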